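The source may report more compounds than this note shows. Statements on the series, on what has been measured and on what is new or still open speak of the compounds shown alone.

Among the two compounds with a measured number, compound 2 `COc1ccc(Cl)c(-c2noc(C(C)C)c2COc2ccc(-c3ccc4c(C(=O)O)cn(C)c4c3)c(C)c2)n1` stands lowest: in a functional assay for agonist activity at Bile acid receptor (Mus musculus), read by a luciferase reporter (a lower number here means that less compound is needed, a higher number that more compound is needed for the effect), compound 2 gives 2000 nM. Within the data shown here, its only neighbour is compound 1 `Cc1cc(OCc2c(-c3c(Cl)ccc(=O)n3C)noc2C(C)C)ccc1-c1ccc2c(C(=O)O)cn(C)c2c1`, which in this assay gives 4000 nM; the step of a 2.0-fold lower number from compound 1 to compound 2 (0.30 log units; within the scatter) is the only one measured, and it stays within the usual scatter of the assay.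

Compound 3 `Cc1cc(OCc2c(-c3[nH]c(=O)ccc3Cl)noc2C(C)C)ccc1-c1ccc2c(C(=O)O)cn(C)c2c1` has not yet been measured. Compared with compound 2, the change is a group of 8 heavy atoms (5 carbon, 1 nitrogen, 1 oxygen, 1 chlorine; one six-membered aromatic ring with 1 hetero atom) in place of a group of 9 heavy atoms (6 carbon, 1 nitrogen, 1 oxygen, 1 chlorine; one six-membered aromatic ring with 1 hetero atom), on an aromatic carbon. Among the measured compounds shown here, compound 3 thus resembles compound 1 more closely than it resembles compound 2, which matters for the expectation: the single measured exchange at this same place, from compound 1 to compound 2, moved the number only within the scatter, and the shared core is otherwise untouched.

The expectation for compound 3 is therefore a value close to those of compound 1 and compound 2, with no change beyond the scatter, expected as a 1.5-fold higher number from compound 2 to compound 3 (0.18 log units; within the scatter). Compound 3 is estimated to give 3000 nM in this assay, within a range of 1000 nM to 10000 nM.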

Compound 3, half-maximal effective concentration: 18000 nM
Estimate against measurement, compound 3: 6.0-fold (0.78 log units) below, and the stated range ends below it.
By their numbers in this assay, from the lowest: compounds 2 and 1 (each within the scatter of the next); then compound 3.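

This position on the five-membered aromatic ring tolerates less than the earlier pair suggested: in this assay there is a 9.0-fold higher number from compound 2 to compound 3 (0.95 log units; beyond the scatter), a change that goes beyond the scatter, unlike the step between the two earlier compounds. The cleanest comparison is with compound 1, since only hydrogen in place of methyl on an aromatic nitrogen separates the two, and it gives a 4.5-fold higher number from compound 1 to compound 3 (0.65 log units; beyond the scatter), so this single methyl makes a visible difference to the number even though the rest of the molecule is unchanged. The entering group of compound 3 also counts a hydrogen-bond donor, whereas the 3-chloro-6-methoxypyridin-2-yl group of compound 2 counts none, but nothing measured here connects that difference to the shift in the number.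

The compounds shown leave open whether an ethyl group or a longer chain on that same aromatic nitrogen would keep the number near that of compound 1, or move it further. They also leave open how an amine or a fluorine in place of the chlorine on this ring would change the number.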